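Carbamoyl to Cyclohexyl on the Amide Chain

A few compounds are considered here, and "the series" means these few. Any claim that something is new, unique, unknown or untested is made for them only; others in the source may bear on it.

Compound 1 `CC(C)C[C@H](N)c1cc(C(F)(F)F)ccc1N1CCN(C(=O)CCC(N)=O)CC1`: > 10000 nM
Compound 2 `Cc1ccc(OCC(=O)N2CCN(c3ccc(C(F)(F)F)cc3[C@@H](N)CC(C)C)CC2)cc1`: 4400 nM
Compound 3 `CC(C)C[C@H](N)c1cc(C(F)(F)F)ccc1N1CCN(C(=O)COc2ccc(Cl)cc2)CC1`: 2900 nM

All three were tested in an assay on HEK293 cells for displacement of a labelled ligand from Melanocortin receptor 4 (Homo sapiens); a lower number here means a stronger inhibitor, a higher number a weaker inhibitor. For compound 1 the result is only a limit of the assay and not a number: the limit of > 10000 nM in this assay, at which 1 of the 3 values shown sits. Compound 4 `CC(C)C[C@H](N)c1cc(C(F)(F)F)ccc1N1CCN(C(=O)CCC2CCCCC2)CC1` differs from compound 1 in one place: cyclohexyl in place of carbamoyl on a saturated chain carbon, two bonds along the chain from a carbonyl carbon. Two measured steps change that same chain end, and both move away from carbamoyl: an at least 2.2-fold lower number from compound 1 to compound 2 (0.35 log units; beyond the scatter) and an at least 3.4-fold lower number from compound 1 to compound 3 (0.53 log units; beyond the scatter). Each gave a lower number, so a lower number, of modest size, is expected here as well: an at least 2.5-fold lower number from compound 1 to compound 4 (0.39 log units; beyond the scatter). The estimate for compound 4 in this assay is 4000 nM, with a range from 1500 nM to 15000 nM, with some chance that only a limit is reported again.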

Compound 4, inhibition constant: 5700 nM
Compound 4: the middle estimate sits 1.4-fold (0.15 log units) below what was measured; low and high end bracket the measured number.
By their numbers in this assay, from the lowest: compounds 3, 2 and 4 (each within the scatter of the next). At a limit, above all of these: compound 1.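

Replacing carbamoyl with cyclohexyl gives an at least 1.7-fold lower number from compound 1 to compound 4 (0.24 log units; that floor lies within the scatter); compound 1 is only a limit, so this step has only a floor: the limit of > 10000 nM in this assay, at which 1 of the 4 values shown sits. What is new is that a carbon-only ring with no hydrogen-bond acceptor cannot be told apart from the 4-chlorophenoxy and 4-methylphenoxy groups, with a 2.0-fold higher number from compound 3 to compound 4 (0.29 log units; within the scatter) and a 1.3-fold higher number from compound 2 to compound 4 (0.11 log units; within the scatter). So neither an aromatic ring nor an ether oxygen is needed to reach this range.

Still open, from the compounds shown here alone, is what an amine or a carboxylic acid would do at this chain end. A plain phenyl ring in place of cyclohexyl is also untested here.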